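The compounds below may be only part of what the source reports. "The series", "measured", "known", "first", "only" and "open" are said of these compounds alone.

Compound 1 `COc1cc(NC(=O)Nc2cc(Nc3ccc(C(C)(C)C)cc3)ncn2)cc(OC)c1` gives 32.7% in a functional assay on HCC827 cells (Homo sapiens) for inhibition, read by MTT assay, with a stated time of 48 h, tested at 10 uM (on this read-out higher numbers stand for more inhibition at the one concentration tested (going by the name of the read-out) and lower numbers for less inhibition), the lower of the two numbers available here. Compound 2 `COc1ccc(OC)c(Nc2cc(NC(=O)Nc3c(Cl)cccc3Cl)ncn2)c1` gives 94.1% in this assay, a gap beyond the usual scatter, but its groups sit in a different arrangement, so it offers no direct guide. Compound 3 `COc1cc(NC(=O)Nc2cc(Nc3cc(C)cc(F)c3)ncn2)cc(OC)c1` is compound 1 with a single change, (3-fluoro-5-methylphenyl in place of 4-(tert-butyl)phenyl on a nitrogen on an aromatic ring). Among the measured compounds shown here, no measured pair shows a swap of this kind, so the expected step is small and of no clear direction beyond the scatter: a number 2.3 percentage points higher from compound 1 to compound 3 (within the scatter). Compound 3 is therefore estimated at 35%, within a range from 10% to 65%.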

Compound 3, a percentage reported as inhibition, at one concentration (the size of the read-out at that concentration, not a potency): 62.1%
For compound 3 the middle estimate is 27.1 percentage points below the measured one; the measured number falls inside the stated range.
By their numbers in this assay, from the lowest: compound 1; then compound 3; then compound 2.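

In this assay, putting 3-fluoro-5-methylphenyl in place of 4-(tert-butyl)phenyl on this nitrogen gives a number 29.4 percentage points higher from compound 1 to compound 3 (beyond the scatter), the first direct sign that the read-out responds to a change at this position. Both groups are single substituted phenyl rings, so the change lies in what the ring carries, though this one swap alters several things at once. Nothing available here explains the step.

From the compounds shown here alone, it remains open whether the fluorine, the methyl or the loss of the tert-butyl carries the step. Also open, going by these compounds, is what a phenyl bearing an amine or a carboxylic acid would give at this nitrogen.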